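From nitro to chloro on compound 2

The source may hold more compounds than are shown below. What is called first, only, known or untested is meant among the compounds shown, and "the series" means these compounds.

Of the compounds shown here, three have been measured so far in an ADME assay on Vero cells (Chlorocebus sabaeus) for cytotoxicity, read by crystal violet staining; a lower number here means that less compound is tolerated, a higher number that more compound is tolerated. Compound 1 `CN1CCN(/N=N/c2ccccc2)CC1` gives 45000 nM, compound 2 `O=[N+]([O-])c1ccc(/N=N/N2CCCC2)cc1` gives 90000 nM, and compound 3 `O=C1CCN(/N=N/c2ccccc2)CC1` gives 60000 nM. Repeated measurements of this kind always scatter somewhat, and compound 2 lies within that scatter of both other compounds, so these numbers do not separate the three.

Compound 4 `Clc1ccc(/N=N/N2CCCC2)cc1` has not yet been measured. It differs from compound 2 in one place, with chloro in place of nitro on an aromatic carbon. Going by the values given here, no two measured compounds differ in just one place, so the data show no direct precedent for this swap. Among the compounds with values here, the only guide is the narrow spread of the numbers: compound 2 at 90000 nM stays within the scatter of compound 1 at 45000 nM, even though their structures are not closely matched. On that thin basis, the expected change in this assay is none beyond the scatter, and the estimated 1.5-fold lower number from compound 2 to compound 4 (0.18 log units; within the scatter) should be read that way. For compound 4 the expected value is 60000 nM, with an estimated range from 25000 nM to 130000 nM.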

Compound 4, half-maximal cytotoxic concentration: > 100000 nM
Compound 4 ended at the assay's limit; the forecaster's own chance of this, stated with the estimate: 10%; middle value at least 1.6-fold (0.22 log units) from the limit.
By their numbers in this assay, from the lowest: compounds 1, 3 and 2 (each within the scatter of the next). At a limit, above all of these: compound 4.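

In this assay compound 4 gives > 100000 nM, which is a limit of the assay and not a number. Going by these compounds alone, this is the first pair in the set that differs in only one place, an aromatic carbon of a six-membered aromatic ring of carbon only, para to a group of 7 heavy atoms, and chloro in place of nitro there gives an at least 1.1-fold higher number from compound 2 to compound 4 (0.04 log units; that floor lies within the scatter). Within the data shown here, the nitro is therefore not needed for the high number of compound 2, and the swap shows no sign of less compound being tolerated, but the size of any rise stays unknown because the step rests only on a floor: the limit of > 100000 nM in this assay, at which 1 of the 4 values shown sits.

As far as these compounds go, how far past that limit compound 4 truly lies remains open, so chloro and nitro cannot be put in order at this position. Also open, from the compounds shown here alone, is how an amine or a carboxylic acid would read at the same place, and whether chloro in place of nitro would behave the same way on a core other than that of compound 2.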